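The source may report more compounds than this note shows. Statements on the series, on what has been measured and on what is new or still open speak of the compounds shown alone.

Measured compounds:
Compound 1, `C=CC1=C(C(=O)Nc2ccccc2OC)C(c2ccc(F)cc2)OC1`, gives in a functional assay on SW480 cells (Homo sapiens) for cytotoxicity, read by MTT assay, with a stated time of 24 h (on this read-out higher numbers stand for weaker inhibition and lower numbers for stronger inhibition), a value of > 100000 nM, which is a limit of the assay and not a number.
Compound 2, `C=CC1=C(C(=O)NCc2ccccc2F)C(c2ccc(F)cc2)OC1`, gives in this assay a value of > 100000 nM, likewise a limit.
Compound 3, `C=CC1=C(C(=O)NCCCCC)C(c2ccc(F)cc2)OC1`, gives in this assay a value of > 100000 nM, again a limit.

Compound 3 therefore stands at the limit, as described by the limit of > 100000 nM in this assay, at which 3 of the 3 values shown sit. Compound 4, `C=CC1=C(C(=O)Nc2cccc(C)c2)C(c2ccc(F)cc2)OC1`, differs from compound 3 by 3-methylphenyl in place of pentyl on an amide-type nitrogen. Among the compounds with values here, three measured steps bear on such exchanges at the amide-type nitrogen: a step that the two limits leave unreadable from compound 1 to compound 3, a step that the two limits leave unreadable from compound 1 to compound 2 and a step that the two limits leave unreadable from compound 2 to compound 3. None of them is readable, since every value involved is a limit; the exchange of an aryl group for a chain, or of one aryl group for another, has so far given nothing that could be measured. For compound 4 the step that the limit leaves unreadable from compound 3 to compound 4 is accordingly expected to be none that the assay can resolve. Compound 4 is estimated to give 150000 nM in this assay, within 50000 nM to 500000 nM, most likely again as a limit.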

Compound 4, half-maximal inhibitory concentration: > 100000 nM
Compound 4 ended at the assay's limit; the forecaster's own chance of this, stated with the estimate: 85%; the middle value is on the limit's open side.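

In this assay compound 4 gives > 100000 nM, which is a limit of the assay and not a number. Its steps from compound 1, compound 2 and compound 3 therefore cannot be read: the limit of > 100000 nM in this assay, at which 4 of the 4 values shown sit.

The compounds shown leave open whether any group on the amide-type nitrogen makes a measurable difference in this assay.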